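This account rests on a few compounds, and the source may have more. Where it says the series, first, only, none or still open, it means among the compounds named here.

In a functional assay on HL-60 cells (Homo sapiens) for antiproliferative activity, read by MTT assay, with a stated time of 24 h (on this read-out lower numbers stand for stronger inhibition and higher numbers for weaker inhibition), compound 1 `CNC(=O)c1ccccc1Oc1nc(Nc2cccc(Br)c2)ncc1Br` gives 38700 nM. Compound 2 `CNC(=O)c1ccccc1Oc1nc(Nc2ccc(Cl)cc2F)ncc1Br` reaches the limit of this assay, > 50000 nM. For the measured compounds named here, the one measured step, an at least 1.2-fold higher number from compound 1 to compound 2 (0.11 log units; that floor lies within the scatter), swaps a different group on the same nitrogen and rests on (the limit of > 50000 nM in this assay, at which 1 of the 2 values shown sits), so its true size is not known. Compound 3 `CNC(=O)c1ccccc1Oc1nc(Nc2cccc(OC)c2)ncc1Br` differs from compound 2 by 3-methoxyphenyl in place of 4-chloro-2-fluorophenyl on a nitrogen on an aromatic ring. Nothing measured fixes the size of this change; since compound 1 with another aromatic ring on that nitrogen gives 38700 nM, a weak value is expected for compound 3, a step of an at least 1.2-fold lower number from compound 2 to compound 3 (0.09 log units; that floor lies within the scatter). The estimate for compound 3 is 40000 nM, between 15000 nM and 150000 nM.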

Compound 3, half-maximal inhibitory concentration: 16200 nM
The estimate for compound 3 lay 2.5-fold (0.39 log units) above the measured number, and the stated range covers the measured number.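

Methoxy in place of bromo on an aromatic carbon gives a 2.4-fold lower number from compound 1 to compound 3 (0.38 log units; beyond the scatter) in this assay and so provides the first step on this ring whose size can be read. 3-Methoxyphenyl in place of 4-chloro-2-fluorophenyl gives an at least 3.0-fold lower number from compound 2 to compound 3 (0.48 log units; beyond the scatter) as a floor only. As far as these compounds go, compound 2 stands at a limit, so the true size of that step stays unknown: the limit of > 50000 nM in this assay, at which 1 of the 3 values shown sits. From the compounds shown here alone, what an amine, a hydroxyl or a longer chain such as ethoxy would give in place of methoxy on that aromatic carbon remains open.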